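The source may report more compounds than this note shows. Statements on the series, on what has been measured and on what is new or still open speak of the compounds shown alone.

Two curcumin-like dienones were measured in a functional assay on LNCaP cells (Homo sapiens) for cytotoxicity, read by MTT assay, with a stated time of 72 h; on this read-out higher numbers stand for weaker inhibition and lower numbers for stronger inhibition. Compound 1, `CC1=CCCC(C)(C)C1/C=C/C(=O)/C=C/c1cccc([N+](=O)[O-])c1`, gives 3300 nM in this assay. Compound 2, `CC1=C(/C=C/C(=O)/C=C/c2cc(C(F)(F)F)cc(C(F)(F)F)c2)C(C)(C)CCC1O`, gives 2100 nM in this assay. Compound 2 has the lower of the two numbers, yet its gap to compound 1 lies within the scatter of repeated measurements, so the two cannot be ordered on the evidence at hand.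

Compound 3, `CC1=C(/C=C/C(=O)/C=C/c2cc(F)cc(C(F)(F)F)c2)C(C)(C)CCC1O`, has not yet been measured. It differs from compound 2 in one place: fluoro in place of trifluoromethyl on an aromatic carbon. Among the compounds with values here, no measured pair shows this exchange, so there is no recorded step to lean on. The expectation for compound 3 is a step of a 1.4-fold higher number from compound 2 to compound 3 (0.15 log units; within the scatter) that stays within the scatter, if anything leaning toward a slightly higher number. Compound 3 is therefore estimated at 3000 nM in this assay, within a range from 1200 nM to 7500 nM.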

Compound 3, half-maximal inhibitory concentration: 1100 nM
For compound 3 the middle estimate is 2.7-fold (0.44 log units) above the measured one, and the stated range ends above it.
By their numbers in this assay, from the lowest: compounds 3, 2 and 1 (each within the scatter of the next, the first and the last beyond it).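

The exchange at this position, meta to a trifluoromethyl group, takes out a group of 4 heavy atoms and puts in one of 1 heavy atom, and it gives a 1.9-fold lower number from compound 2 to compound 3 (0.28 log units; within the scatter) in this assay. This is the first recorded step among these compounds, and it shows that the position can carry either fluoro or trifluoromethyl without a difference that can be told from the scatter, so compound 2 and compound 3 cannot be ordered. Nothing measured here bears on what lies behind this result.

As far as these compounds go, whether an amine, a carboxylic acid or a longer chain at this position would stay in the same range remains open. So does whether fluoro can also take the place of the remaining trifluoromethyl group.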